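From Nitro to Cyano on a Shared Core

The compounds below may be only part of what the source reports. "The series", "measured", "known", "first", "only" and "open" are said of these compounds alone.

compound 1 `CC(C)(C)NC(=O)Nc1nc2ccc(Br)cc2s1` gives 23300 nM
compound 2 `CC(C)NC(=O)Nc1nc2ccc([N+](=O)[O-])cc2s1` gives "not determined" (no result reported)
compound 3 `CC(C)(C)NC(=O)Nc1nc2ccc([N+](=O)[O-])cc2s1` gives 19500 nM

In a functional assay (thoracic aorta, Rattus norvegicus, strain Wistar), in the presence of a further agent that is not named here (on this read-out higher numbers stand for an effect only at larger amounts of compound and lower numbers for an effect already at smaller amounts), compound 3 stands at 19500 nM and so level with compound 1, within the scatter, while compound 2 offers no number for comparison. Compound 4 `CC(C)(C)NC(=O)Nc1nc2ccc(C#N)cc2s1` differs from compound 3 by cyano in place of nitro on an aromatic carbon and is still to be measured. Among the compounds with values here, one measured step bears on this change, the one with nitro in place of bromo on an aromatic carbon, namely a 1.2-fold lower number from compound 1 to compound 3 (0.08 log units; within the scatter) and it stays small. A single step is thin evidence, yet nothing in it points to a shift in this assay in either direction. The expected step is a 1.0-fold higher number from compound 3 to compound 4 (0.01 log units; within the scatter) and so none beyond the scatter is anticipated. For compound 4 the estimate is 20000 nM with an expected range from 10000 nM to 40000 nM on repeated measurement.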

Compound 4, half-maximal effective concentration: 15600 nM
Compound 4: the middle estimate sits 1.3-fold (0.11 log units) above what was measured; low and high end bracket the measured number.
By their numbers in this assay, from the lowest: compounds 4, 3 and 1 (each within the scatter of the next).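

In this assay, cyano now joins bromo and nitro as a third group on this aromatic carbon, and swapping it for nitro gives a 1.3-fold lower number from compound 3 to compound 4 (0.10 log units; within the scatter), while swapping it for bromo gives a 1.5-fold lower number from compound 1 to compound 4 (0.17 log units; within the scatter). Within the data shown here, the earlier compounds offered only one comparison at this position, whereas compound 1, compound 3 and compound 4 now stand level across three different groups, and even the change from 3 heavy atoms and a double bond to 2 heavy atoms and a triple bond leaves the number within the scatter. Nothing measured alongside these numbers offers an explanation for this.

Going by these compounds, whether an amine or a carboxylic acid on this aromatic carbon would also stay level with these three groups remains open. On these data alone, it is equally open whether a longer chain at the other end of the shared core would shift the number.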